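Amide to Ester on a Shared Core

The compounds below may be only part of what the source reports. "The series", "measured", "known", "first", "only" and "open" are said of these compounds alone.

Three compounds have been measured in an assay on membranes from HEK293 cells for displacement of a labelled ligand from adenosine receptor A2b (Homo sapiens), read by scintillation counting, with a stated time of 30 min, tested at 1 uM; a higher number here means more inhibition at the concentration tested (going by the name of the read-out), a lower number less inhibition:

compound 1 `CCNC(=O)C1=C(C)NC(=O)NC1c1ccoc1` gives 2%
compound 2 `CCNC(=O)C1=C(C)NC(=O)NC1c1cccs1` gives 1%
compound 3 `CCNC(=O)C1=C(C)NC(=O)NC1c1ccsc1` gives 1%

Compound 3 stands level with compound 2 at the digits printed, and together they are the lowest of the three numbers. Its nearest neighbour is compound 2, with no change at the digits printed from compound 2 to compound 3 (within the scatter); the furthest is compound 1, with a number 1 percentage points lower from compound 1 to compound 3 (within the scatter). The third step, a number 1 percentage points lower from compound 1 to compound 2 (within the scatter), is of the same small size. All three steps concern the group on the saturated ring carbon, and none of them moves the number beyond the scatter.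

Compound 4 `CCC(C)OC(=O)C1=C(C)NC(=O)NC1c1ccsc1` differs from compound 3 at a different place: sec-butoxy in place of ethylamino on a carbonyl carbon. For the measured compounds named here, no measured step touches the carbonyl carbon, so the only guidance is that every change so far has left the read-out near its low level. On that basis the step from compound 3 to compound 4 is expected to be a number 2 percentage points higher from compound 3 to compound 4 (within the scatter), with no movement beyond the scatter. Compound 4 is therefore estimated at 3%, in a range from -7% to 13%.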

Compound 4, a percentage reported as inhibition, at one concentration (the size of the read-out at that concentration, not a potency): 39%
Compound 4: the middle estimate sits 36 percentage points below what was measured; measured number above the stated range.
By their numbers in this assay, from the lowest: compounds 2, 3 and 1 (each within the scatter of the next); then compound 4.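

In this assay, the group on the carbonyl carbon proves to be a far more sensitive place than the saturated ring carbon: sec-butoxy in place of ethylamino gives a number 38 percentage points higher from compound 3 to compound 4 (beyond the scatter), whereas every exchange of the ring group stayed within the scatter. This single step changes the heavy atoms, the hydrogen-bond donor and the hydrogen-bond acceptor together, so it cannot assign the rise to any one of these. Nothing available explains the rise.

As far as these compounds go, whether the rise follows from the oxygen link or from the longer branched chain stays open, and an ethoxy group or a sec-butylamino group on the same carbonyl carbon would separate the two. Also open, from the compounds shown here alone, is whether furan-3-yl or thiophen-2-yl on the saturated ring carbon would read differently alongside sec-butoxy.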